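The source may report more compounds than this note shows. Statements on the series, on what has been measured and on what is new or still open speak of the compounds shown alone.

Compound 1 `CCCCc1oc2ccccc2c1C(=O)c1ccc(OCC(N)=O)cc1` is the parent of the series and is tested in a functional assay on HL-60 cells (Homo sapiens) for antiproliferative activity, read by MTT assay, with a stated time of 24 h; a lower number here means a stronger inhibitor, a higher number a weaker inhibitor. In this assay compound 1 gives only a limit, > 50000 nM. Compound 2 `CCCCc1oc2ccccc2c1C(=O)c1ccc(OCC(=O)N[C@H](C)c2ccccc2)cc1`, with 1-phenylethyl in place of hydrogen on an amide-type nitrogen, likewise gives only a limit in this assay, > 50000 nM. The step that the two limits leave unreadable from compound 1 to compound 2 cannot be read because of the limit of > 50000 nM in this assay, at which 2 of the 2 values shown sit. Compound 3 `CCCCc1oc2ccccc2c1C(=O)c1ccc(OCCCC(=O)N2CCCCC2)cc1` differs from compound 1 by 2-((piperidin-1-yl)carbonyl)ethyl in place of carbamoyl on a saturated chain carbon bound to an oxygen on an aromatic ring. No readable measured step bears on this change. Compound 3 is therefore expected to remain at the limit, and the step that the limit leaves unreadable from compound 1 to compound 3 is estimated as not readable. The value of compound 3 is estimated at 60000 nM, within 15000 nM to 200000 nM.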

Compound 3, half-maximal inhibitory concentration: 31900 nM
Compound 3: the middle estimate sits 1.9-fold (0.27 log units) above what was measured; the range from low to high includes it.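

In this assay, among these compounds, compound 3 gives the first value of the series that is a number rather than a limit, 31900 nM, so a change at this position can bring a readable result. The change reads as an at least 1.5-fold lower number from compound 1 to compound 3 (0.19 log units; that floor lies within the scatter), and as an at least 1.5-fold lower number from compound 2 to compound 3 (0.19 log units; that floor lies within the scatter). The true size of both steps stays unread because the other values are limits: the limit of > 50000 nM in this assay, at which 2 of the 3 values shown sit.

The compounds shown do not separate the longer chain from the piperidine ring, as 3-carbamoylpropyl would. Going by these compounds, a morpholine amide or a carboxylic acid on the same chain also remains open.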